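Nitro for Fluoro on the Cinnamamide Aryl Ring

A few compounds are considered here, and "the series" means these few. Any claim that something is new, unique, unknown or untested is made for them only; others in the source may bear on it.

compound 1 `COc1cccc(/C=C/C(=O)Nc2cc(OC)c(OC)c(OC)c2)c1`: 3200 nM
compound 2 `COc1ccc(C(=O)c2cc(OC)c(OC)c(OC)c2)cc1NC(=O)/C=C/c1ccc(F)cc1`: 3900 nM

Both were tested in a functional assay on DU-145 cells (Homo sapiens) for cytotoxicity, read by MTT assay, with a stated time of 72 h; on this read-out lower numbers stand for stronger inhibition and higher numbers for weaker inhibition. Compound 2 stands at the upper end of the two numbers, yet its gap to compound 1 lies within the scatter, so the two are not told apart. Going by these compounds, compound 3 `COc1ccc(C(=O)c2cc(OC)c(OC)c(OC)c2)cc1NC(=O)/C=C/c1ccc([N+](=O)[O-])cc1` is untested; it differs from compound 2 by nitro in place of fluoro on an aromatic carbon, a nitro in place of fluoro on an aromatic carbon. For the measured compounds named here, no measured pair covers this change, so in this assay a step of little size is expected, if any then toward a lower number, and likely not beyond the scatter. Compound 3 is expected to give 3000 nM, within 800 nM to 12000 nM, an expected step of a 1.3-fold lower number from compound 2 to compound 3 (0.11 log units; within the scatter).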

Compound 3, half-maximal inhibitory concentration: 15600 nM
Compound 3: middle estimate off by 5.2-fold (0.72 log units), on the low side, outside the stated range (above it).
By their numbers in this assay, from the lowest: compounds 1 and 2 (each within the scatter of the next); then compound 3.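

In this assay, nitro in place of fluoro on the aromatic carbon para to a large group gives a 4.0-fold higher number from compound 2 to compound 3 (0.60 log units; beyond the scatter). This shows that the position is not indifferent to the group it carries, and that this change moves the read-out toward weaker inhibition. No measurement shown bears on why the step arises.

Going by these compounds, whether an amine, a carboxylic acid or plain hydrogen at this place would stay with compound 2 or move with compound 3 remains open. Compound 1 differs from both in more than one place and cannot settle this.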